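A few compounds are considered here, and "the series" means these few. Any claim that something is new, unique, unknown or untested is made for them only; others in the source may bear on it.

In a functional assay on LNCaP cells (Homo sapiens) for cytotoxicity, read by MTT assay (on this read-out lower numbers stand for stronger inhibition and higher numbers for weaker inhibition), three related compounds have been examined so far. Compound 1 `COc1ccc2cc([C@H](C)c3nnc(SCc4c(C)cc(C)cc4C)n3-c3cccc(Cl)c3)ccc2c1` gives <= 400000 nM as its result, which is a limit of the assay and not a number. Compound 2 `COc1ccc(CSc2nnc([C@@H](C)c3ccc4cc(OC)ccc4c3)n2-c2ccc(Cl)cc2)cc1` also gives only a limit, <= 400000 nM in this case. For compound 3 `COc1ccc2cc([C@H](C)c3n[nH]c(=S)n3-c3cccc(Cl)c3)ccc2c1` the entry reads "not determined" (no result reported) and supplies no number. Compound 2 therefore stands at the limit of <= 400000 nM in this assay, at which 2 of the 3 values shown sit, and has no exact figure to place it.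

Compound 4 `COc1ccc2cc([C@H](C)c3nnc(SCc4ccc(C)cc4)n3-c3ccc(Cl)cc3)ccc2c1` departs from compound 2 in one place, with methyl in place of methoxy on an aromatic carbon of a six-membered aromatic ring of carbon only, para to a large group (4-methoxybenzyl becomes 4-methylbenzyl) methyl in place of methoxy on an aromatic carbon in the count of atoms.

Within the data shown here, no measured step offers guidance, so only a modest shift is expected, and the estimated change a step that the limit leaves unreadable from compound 2 to compound 4 toward stronger inhibition is read against a limit. The estimate for compound 4 is 150000 nM in this read-out, with an expected range from 30000 nM up to 400000 nM for the coming measurement.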

Compound 4, half-maximal inhibitory concentration: 52200 nM
Compound 4: the middle estimate sits 2.9-fold (0.46 log units) above what was measured; measured number inside the range.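

In this assay the step between compound 2 and compound 4 cannot be read, because compound 2 gives only a limit and no exact figure: the limit of <= 400000 nM in this assay, at which 2 of the 4 values shown sit.

The compounds shown leave open how large a change, if any, methyl in place of methoxy brings here.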